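Nitrile series: pyridinylsulfanyl replacing carbamoylphenoxy

This account rests on a few compounds, and the source may have more. Where it says the series, first, only, none or still open, it means among the compounds named here.

Measured compounds:
compound 1 `CCC(=O)Nc1ccc(OCc2cc3cnc(C#N)nc3n2CCC2CCCCC2)cc1` gives 12 nM
compound 2 `N#Cc1ncc2cc(COc3ccc(C(N)=O)cc3)n(CCC3CCCCC3)c2n1` gives 2 nM
compound 3 `CC(C)(C)CCn1c(Cc2ccc(Cl)cc2)cc2cnc(C#N)nc21` gives 2 nM

In an assay on isolated protein for inhibition of cathepsin S (Homo sapiens), read by fluorescence (on this read-out lower numbers stand for stronger inhibition and higher numbers for weaker inhibition), compound 2 stands level with compound 3 at the digits given, the two together the lowest of the three numbers; compound 1 sits furthest away, the step from it being a 6.0-fold lower number from compound 1 to compound 2 (0.78 log units; beyond the scatter).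

The next compound, compound 4 `N#Cc1ncc2cc(CSc3ccncc3)n(CCC3CCCCC3)c2n1`, differs from compound 2 in one place: (pyridin-4-yl)sulfanyl in place of 4-carbamoylphenoxy on a saturated chain carbon bound to an aromatic carbon. Among the measured compounds shown here, none of the measured steps covers this change. For the measured compounds named here, the one step that exists, a 6.0-fold lower number from compound 1 to compound 2 (0.78 log units; beyond the scatter), altered only the substituent on the aromatic ring that now leaves altogether, so it gives no direct guidance. Going by the values given here, compound 3 carries a 4-chlorophenylmethyl group and a different chain, differing in more than one place, and shows only that a carbocyclic ring without the ether oxygen can still give 2 nM.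

Among the compounds with values here, with no bearing step, the expectation is a modest rise in this assay for compound 4, a 4.0-fold higher number from compound 2 to compound 4 (0.60 log units; beyond the scatter), since the ether and the carbamoyl-bearing ring are both lost. The estimate for compound 4 is 8 nM, range 2 nM to 40 nM.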

Compound 4, half-maximal inhibitory concentration: 6 nM
Compound 4: middle estimate off by 1.3-fold (0.12 log units), on the high side, within the range that was stated.
By their numbers in this assay, from the lowest: compounds 2 and 3 (each within the scatter of the next); then compounds 4 and 1 (each within the scatter of the next).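

In this assay, (pyridin-4-yl)sulfanyl in place of 4-carbamoylphenoxy on a saturated chain carbon bound to an aromatic carbon gives a 3.0-fold higher number from compound 2 to compound 4 (0.48 log units; beyond the scatter), the first step shown that replaces the whole group at this position rather than a substituent on its ring. Neither the carbamoyl group nor the ether oxygen is required for compound 4 to reach 6 nM, although the step remains beyond the scatter and the group of compound 2 keeps the lower number. No measurement shown bears on the reason for this step.

The ring and the linking atom change together here, so their separate shares in the step remain unresolved. A 4-carbamoylphenylsulfanyl group would isolate the sulfur, and a phenylsulfanyl group would test the ring nitrogen of the pyridine.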